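Piperazine amides on the shared core: methyl to ethyl

A few compounds are considered here, and "the series" means these few. Any claim that something is new, unique, unknown or untested is made for them only; others in the source may bear on it.

Measured so far:
compound 1 `Cn1c(-c2ccc(NC(=O)CSc3nc4ccccc4s3)cc2)nc(-c2ccccc2)c1-c1ccccc1`: 76.6%
compound 2 `CN1CCN(CC(=O)Nc2ccc(-c3nc(-c4ccccc4)c(-c4ccccc4)n3C)cc2)CC1`: 50.3%

In a functional assay on MCF7 cells (Homo sapiens) for cytotoxicity, read by MTT assay, with a stated time of 24 h, tested at 80 ug/mL (a lower number here means a weaker effect, a higher number a stronger effect of the compound at the concentration tested), compound 1 gives 76.6%, while compound 2 gives 50.3%, the lowest of the two numbers. Within the data shown here, the only measured step, a number 26.3 percentage points lower from compound 1 to compound 2 (beyond the scatter), concerns the replacement of (1,3-benzothiazol-2-yl)sulfanyl by 4-methylpiperazin-1-yl. Compound 3 `CCN1CCN(CC(=O)Nc2ccc(-c3nc(-c4ccccc4)c(-c4ccccc4)n3C)cc2)CC1` differs from compound 2 by methyl in place of hydrogen on a saturated chain carbon bound to an amine nitrogen in a ring, read one bond further out as 4-methylpiperazin-1-yl to 4-ethylpiperazin-1-yl. Among the measured compounds shown here, no measured step touches this change, so nothing here points to a shift beyond the scatter in this assay. Compound 3 is expected to give 52%, within 38% to 66%, an estimated step of a number 1.7 percentage points higher from compound 2 to compound 3 (within the scatter).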

Compound 3, a percentage reported as activity, at one concentration (the size of the read-out at that concentration, not a potency): 46.3%
Compound 3: the middle estimate sits 5.7 percentage points above what was measured; the range from low to high includes it.
By their numbers in this assay, from the lowest: compounds 3 and 2 (each within the scatter of the next); then compound 1.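

In this assay the change from 4-methylpiperazin-1-yl to 4-ethylpiperazin-1-yl amounts to a number 4 percentage points lower from compound 2 to compound 3 (within the scatter), so at this position the added methyl leaves no readable difference. With 4-ethylpiperazin-1-yl in place of (1,3-benzothiazol-2-yl)sulfanyl the gap remains, at a number 30.3 percentage points lower from compound 1 to compound 3 (beyond the scatter), so the ethyl piperazine amide also falls short of compound 1. No available evidence accounts for either step.

From the compounds shown here alone, whether a longer alkyl chain or a benzyl group on the piperazine nitrogen would shift the read-out remains open. So does the effect of a morpholine or piperidine in place of the piperazine.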